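Benzylamide in place of a cyclic amide: stability expected to hold

The compounds below may be only part of what the source reports. "The series", "measured", "known", "first", "only" and "open" are said of these compounds alone.

Measured compounds:
Compound 1, `C=CC(=O)N1CC(NC(=O)Cn2c(C)c(C(=O)N3CCc4c(cccc4OC)C3)c3cc(Br)cc(C)c32)C1`, gives 1.67 h.
Compound 2, `C=CC(=O)N1CC(NC(=O)Cn2cc(C(=O)N3CCc4c(F)cccc4C3)c3cc(Br)ccc32)C1`, gives 1.67 h.
Compound 3, `C=CC(=O)N1CC(NC(=O)Cn2c(C)c(C(=O)N3CCc4c(cccc4OC)C3)c3cc(Cl)ccc32)C1`, gives 1.67 h.

All three values come from a physicochemical assay for pharmacokinetics, read by LC-MS, in phosphate buffer, at pH 7.4, in the presence of a further agent that is not named here; a lower number here means that the compound disappears faster, a higher number that the compound lasts longer. On these numbers compound 2 stands level with compound 1 and compound 3 at the digits shown; its nearest neighbour is compound 1 and its furthest is compound 3, and in both cases the gap is within the scatter, so no order among the three can be read from them.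

Compound 4, `C=CC(=O)N1CC(NC(=O)Cn2cc(C(=O)NCc3ccccc3)c3cc(Br)ccc32)C1`, has not yet been measured. It differs from compound 2 in one place: benzylamino in place of 5-fluoro-1,2,3,4-tetrahydroisoquinolin-2-yl on a carbonyl carbon. For the measured compounds named here, no step between two measured compounds covers this change, so there is nothing in the numbers that speaks for a shift in either direction. Going by the values given here, the three measured compounds, which differ among themselves at several places on the shared core and on the amide side, all give the same half-life, and that is the only guide available.

On that basis the half-life of compound 4 in this assay is expected to stay where the measured compounds stand, with a step of no change at the digits printed from compound 2 to compound 4 (within the scatter), which is none beyond the scatter. The estimate for compound 4 is 1.67 h, with a range from 0.8 h to 3.5 h.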

Compound 4, half-life: 1.67 h
Estimate against measurement, compound 4: no gap at the digits printed; the measured number falls inside the stated range.
By their numbers in this assay, from the lowest: compounds 1, 2, 3 and 4 (each within the scatter of the next).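

In this assay, the exchange of 5-fluoro-1,2,3,4-tetrahydroisoquinolin-2-yl for benzylamino on a carbonyl carbon gives no change at the digits printed from compound 2 to compound 4 (within the scatter), and this is the only step among the compounds shown that isolates a single place. For the compounds shown here, at this position, the half-life therefore does not register the loss of the six-membered non-aromatic ring and the fluorine, or the entry of the amide hydrogen, whereas the earlier compounds, which differ in several places at once, could not show this for any one change. No measurement shown bears on what lies behind this result.

As far as these compounds go, it remains open whether the half-life would also hold with a carboxylic acid or an amine on the same carbonyl carbon, or with a longer chain between the amide nitrogen and the aromatic ring of the benzylamino group. Going by these compounds alone, the contribution of every other place on the shared core also remains unseparated, with this single step as the only direct comparison available.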